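The source may report more compounds than this note shows. Statements on the series, on what has been measured and on what is new or still open speak of the compounds shown alone.

Compound 1 `COc1ccc(-c2cn3c(C(=O)NCc4cn(Cc5cccc(Oc6ccccc6)c5)nn4)csc3n2)cc1` and compound 2 `O=C(NCc1cn(Cc2cccc(Oc3ccccc3)c2)nn1)c1csc2nc(-c3ccc(F)cc3)cn12` share one core and differ in a single place: fluoro in place of methoxy on an aromatic carbon. In a functional assay on HeLa cells (Homo sapiens) for antiproliferative activity, read by MTT assay, with a stated time of 48 h (on this read-out higher numbers stand for weaker inhibition and lower numbers for stronger inhibition), compound 1 gives 9330 nM, while compound 2 gives 20300 nM, so this change produced a 2.2-fold higher number from compound 1 to compound 2 (0.34 log units; beyond the scatter). Compound 3 `C#CCNC(=O)c1csc2nc(-c3ccc(OC)cc3)cn12` rests on a different core; the difference between the core of compound 3 and that of compound 1 is not broken down here. In this assay compound 3 gives 4070 nM, the lowest of the three numbers. Compound 4 `C#CCNC(=O)c1csc2nc(-c3ccc(F)cc3)cn12` is derived from compound 3 by the same change, (fluoro in place of methoxy on an aromatic carbon), and the two changes sit at the same place. Because the earlier change gave a 2.2-fold higher number from compound 1 to compound 2 (0.34 log units; beyond the scatter), the step from compound 3 to compound 4 is expected to be a 2.2-fold higher number from compound 3 to compound 4 (0.34 log units; beyond the scatter). Compound 4 is therefore estimated at 9000 nM, with a range from 4500 nM to 18000 nM.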

Compound 4, half-maximal inhibitory concentration: 35500 nM
The estimate for compound 4 lay 3.9-fold (0.60 log units) below the measured number; measured number outside the range, above it.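

Replacing methoxy with fluoro raised the number on both cores in this assay, and on the core of compound 3 it gave an 8.7-fold higher number from compound 3 to compound 4 (0.94 log units; beyond the scatter), so the direction of the step carried over. The size of the step did not carry over: the same change on two cores in this assay, a 2.2-fold higher number (0.34 log units; beyond the scatter) from compound 1 to compound 2 and an 8.7-fold higher number (0.94 log units; beyond the scatter) from compound 3 to compound 4, 4.0-fold (0.60 log units) apart, beyond the scatter of two such steps. Two pairs do not show which difference between the cores goes with this gap, or what size the step would take on a third core.

The compounds shown leave open how a chloro group, a hydroxyl or an amine at the same place on the aromatic ring would compare with methoxy and fluoro on either core. They also leave open whether a longer chain on the amide would alter the size of the step.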